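A few compounds are considered here, and "the series" means these few. Any claim that something is new, unique, unknown or untested is made for them only; others in the source may bear on it.

Compound 1 (`Cc1cc(C(=O)NCCCCCCS)[nH]n1`) is the starting point of this step. In a functional assay on MCF7 cells (Homo sapiens) for inhibition, read by MTT assay, with a stated time of 96 h (a higher number here means a weaker inhibitor of growth, a lower number a stronger inhibitor of growth), compound 1 gives > 50000 nM as a limit of the assay and not as a number. Compound 2 (`O=C(NCCCCCCS)c1cc(-c2ccc3ccccc3c2)n[nH]1`) gives > 50000 nM as a limit too. Going by the values given here, compound 3 (`CCCCCCCC/C=C\CCCCCCCC(=O)SCCCCCCNC(=O)c1cc(-c2ccncc2)n[nH]1`) gives 31100 nM as a measured number, the only one so far. Compound 1 thus stands with compound 2 on the limit of > 50000 nM in this assay, at which 2 of the 3 values shown sit, and has no number of its own.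

Compound 4 (`O=C(NCCCCCCS)c1cc(C2CCCCC2)n[nH]1`) has not yet been measured. It differs from compound 1 by a single change (cyclohexyl in place of methyl on an aromatic carbon), cyclohexyl in place of methyl on an aromatic carbon. Among the compounds with values here, no measured step covers a change of this kind, so the expectation rests on thin ground. Little movement is expected in this assay for this change because of the limit of > 50000 nM in this assay, at which 2 of the 3 values shown sit, which holds for compound 1 and compound 2 alike. The estimated step is a number no higher from compound 1 to compound 4 (the limit leaves the size open) and is expected to stay within the scatter. Compound 4 is estimated at 50000 nM with an expected range from 25000 nM to 100000 nM and may well turn out to be only a limit.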

Compound 4, concentration for 50% growth inhibition: > 50000 nM
Compound 4: a limit, no number (the forecaster's own chance of this, stated with the estimate: 70%); the middle value lies on the limit itself.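

Compound 1 and compound 4 both stand as limits and not as numbers in this assay, so no step can be read between them: the limit of > 50000 nM in this assay, at which 3 of the 4 values shown sit.

The compounds shown leave open whether cyclohexyl in place of methyl on an aromatic carbon changes growth inhibition at all, and by how much.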